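Aortic inhibition series: methyl to methoxy on the aryl ring

A few compounds are considered here, and "the series" means these few. Any claim that something is new, unique, unknown or untested is made for them only; others in the source may bear on it.

Measured compounds:
compound 1 `CCOc1nc(-c2nc3ccccc3n2C)cc(-c2ccc(Cl)cc2)c1C#N` — 293000 nM
compound 2 `CCOc1nc(-c2nc3ccccc3n2C)cc(-c2ccc(C)cc2)c1C#N` — 400000 nM

In a functional assay on aorta (Rattus norvegicus, strain Wister) (on this read-out higher numbers stand for weaker inhibition and lower numbers for stronger inhibition), compound 2 gives 400000 nM, the higher of the two numbers shown, though its gap to compound 1 is within the scatter. Compound 3 `CCOc1nc(-c2nc3ccccc3n2C)cc(-c2ccc(OC)cc2)c1C#N` differs from compound 2 by methoxy in place of methyl on an aromatic carbon. For the measured compounds named here, the only measured step, a 1.4-fold higher number from compound 1 to compound 2 (0.14 log units; within the scatter), concerns a different exchange at the same aromatic carbon and lies within the scatter, so it gives little direction. Compound 3 is therefore expected to stay near compound 2, with no step beyond the scatter: no change at the digits printed from compound 2 to compound 3 (within the scatter). The estimate for compound 3 is 400000 nM, ranging from 180000 nM to 900000 nM.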

Compound 3, half-maximal inhibitory concentration: 436000 nM
Beside the measured number, compound 3's estimate is 1.1-fold (0.04 log units) below it, and the stated range covers the measured number.
By their numbers in this assay, from the lowest: compounds 1, 2 and 3 (each within the scatter of the next).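

In this assay, methoxy in place of methyl on this aromatic carbon, para to a large group, gives a 1.1-fold higher number from compound 2 to compound 3 (0.04 log units; within the scatter) and methoxy in place of chloro gives a 1.5-fold higher number from compound 1 to compound 3 (0.17 log units; within the scatter) as a second step within the scatter. Chloro, methyl and methoxy are thus not told apart at this position, even though methoxy brings a hydrogen-bond acceptor that the methyl group lacks. No measured evidence bears on this result. The compounds shown leave open whether an amine, a carboxylic acid or a longer alkoxy chain on this carbon would give a step beyond the scatter.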